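A few compounds are considered here, and "the series" means these few. Any claim that something is new, unique, unknown or untested is made for them only; others in the source may bear on it.

Working notes on the series. Compound 1 `Nc1cc(N)c2nc(-c3ccccc3)c(Oc3ccc(Cl)c(Cl)c3)nc2c1` carries a 3,4-dichlorophenoxy group on the shared core. In a functional assay on MOLT-4 cells (Homo sapiens) for inhibition, read by sulforhodamine B assay, with a stated time of 48 h (a lower number here means that less compound is tolerated, a higher number that more compound is tolerated), compound 1 returns only a limit, < 100000 nM, and not a number. Compound 2 `Nc1cc(N)c2nc(-c3ccccc3)c(NCc3ccc(Cl)c(Cl)c3)nc2c1` likewise gives a limit in this assay, < 100000 nM. Compound 3 `COc1cc(CNc2nc3cc(N)cc(N)c3nc2-c2ccccc2)cc(OC)c1OC` also ends at a limit in this assay, < 50200 nM. Compound 1 therefore stands among values that are all limits, as shown by the limit of < 100000 nM in this assay, at which 2 of the 3 values shown sit, and (the limit of < 50200 nM in this assay, at which 1 of the 3 values shown sits); nothing in the numbers separates the three compounds, and no step between measured compounds can be drawn.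

Compound 4 `COc1ccc(Sc2nc3cc(N)cc(N)c3nc2-c2ccccc2)cc1` remains to be measured in this assay. Its change from compound 1 is (4-methoxyphenyl)sulfanyl in place of 3,4-dichlorophenoxy on an aromatic carbon, in words (4-methoxyphenyl)sulfanyl in place of 3,4-dichlorophenoxy on an aromatic carbon. With every measured value a limit, no direction can be read from the series, and the expected step is none beyond the scatter. Compound 4 is expected to come out near 30000 nM, with a range from 5000 nM to 100000 nM. As a step this expectation corresponds to a step that the limit leaves unreadable from compound 1 to compound 4, an estimate only, and a further limit rather than a number is itself a likely outcome.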

Compound 4, concentration lethal to 50% of the cells: < 100000 nM
Compound 4 ended at the assay's limit (the forecaster's own chance of this, stated with the estimate: 60%); the middle value lies beyond the limit too.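

Compound 4, like compound 1, gives only a limit and not a number in this assay, so no step can be read between compound 1 and compound 4. The compounds shown leave open whether (4-methoxyphenyl)sulfanyl and 3,4-dichlorophenoxy differ at all in this assay.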